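The source may report more compounds than this note shows. Statements on the series, on what has been measured and on what is new or still open speak of the compounds shown alone.

Values in a functional assay on Jurkat cells (Homo sapiens) for cytotoxicity, read by MTT assay, with a stated time of 72 h; on this read-out higher numbers stand for weaker inhibition and lower numbers for stronger inhibition:
- Compound 1 `O=C(Nc1ccccc1)Nc1ccc(C(=O)NO)cc1`: 2500 nM
- Compound 2 `O=C(Nc1ccc(Cl)cc1)Nc1ccc(C(=O)NO)cc1`: 1060 nM
- Compound 3 `O=C(Nc1ccc(C(=O)NO)cc1)Nc1ccc([N+](=O)[O-])cc1`: 12700 nM

Compound 3 has the highest number of the three, and so the weakest inhibition, as a 5.1-fold higher number from compound 1 to compound 3 (0.71 log units; beyond the scatter) and a 12-fold higher number from compound 2 to compound 3 (1.08 log units; beyond the scatter) show. Compound 4 `O=C(CCc1ccc(NC(=O)Nc2ccc([N+](=O)[O-])cc2)cc1)NO` has 2-(hydroxycarbamoyl)ethyl in place of hydroxycarbamoyl on an aromatic carbon.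

Among the measured compounds shown here, no measured step makes this change. Those steps only swap hydrogen, chloro or nitro, and they show that small edits here can give modest to large shifts, such as a 12-fold higher number from compound 2 to compound 3 (1.08 log units; beyond the scatter). With compound 3 at 12700 nM, the top of this small series, a modest move to a lower number is expected, though the direction is uncertain. The expected change is a 3.2-fold lower number from compound 3 to compound 4 (0.50 log units; beyond the scatter). Compound 4 is estimated at 4000 nM, within an expected range of 800 nM to 16000 nM.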

Compound 4, half-maximal inhibitory concentration: 810 nM
For compound 4 the middle estimate is 4.9-fold (0.69 log units) above the measured one; the range from low to high includes it.
By their numbers in this assay, from the lowest: compounds 4 and 2 (each within the scatter of the next); then compound 1; then compound 3.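

In this assay, replacing hydroxycarbamoyl with 2-(hydroxycarbamoyl)ethyl gives a 16-fold lower number from compound 3 to compound 4 (1.20 log units; beyond the scatter). Among the compounds shown here, the earlier steps swapped only hydrogen, chloro or nitro, so this is the first sign that the group at this position also shifts the number strongly. No measurement here gives a reason for the shift.

As far as these compounds go, it remains open whether a longer chain ending in hydroxycarbamoyl would lower the number further, or whether a carboxylic acid could replace hydroxycarbamoyl. From the compounds shown here alone, it is also open whether 2-(hydroxycarbamoyl)ethyl would give a similar step with chloro in place of nitro.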